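The source may hold more compounds than are shown below. What is called first, only, known or untested is meant among the compounds shown, and "the series" means these compounds.

Among the measured compounds shown here, in an assay on HEK293 cells for inhibition of N-acylethanolamine-hydrolyzing acid amidase (Homo sapiens), read by fluorescence, with stated times of 10 min and 50 min (a higher number here means a weaker inhibitor, a lower number a stronger inhibitor), compound 3 `O=C(N[C@H]1CNC1=O)OCc1ccc(-c2cocn2)cc1` gives 1880 nM, the highest of the three numbers measured so far. Compound 1 `CCCc1ccc(COC(=O)N[C@H]2CNC2=O)cc1` gives 52 nM, and compound 2 `CCCCc1ccc(COC(=O)N[C@H]2CNC2=O)cc1` gives 23 nM. Compound 4 `CCc1ccc(COC(=O)N[C@H]2CNC2=O)cc1` has not yet been measured; it carries ethyl in place of 1,3-oxazol-4-yl on an aromatic carbon. For the measured compounds named here, two measured steps bear on this change: a 36-fold higher number from compound 1 to compound 3 (1.56 log units; beyond the scatter) and an 82-fold higher number from compound 2 to compound 3 (1.91 log units; beyond the scatter), both large. Going the other way, from the 1,3-oxazol-4-yl back to a plain chain, should therefore give a large step downward in this assay. Among the chains, a 2.3-fold lower number from compound 1 to compound 2 (0.35 log units; beyond the scatter) is modest, and ethyl is the shortest of the three, so compound 4 is expected to land somewhat above compound 1 rather than below it. Compound 4 is expected to give 100 nM, within a range of 40 nM to 300 nM. The expected step is a 19-fold lower number from compound 3 to compound 4 (1.27 log units; beyond the scatter).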

Compound 4, half-maximal inhibitory concentration: 160 nM
Compound 4: middle estimate off by 1.6-fold (0.20 log units), on the low side, within the range that was stated.
By their numbers in this assay, from the lowest: compound 2; then compound 1; then compound 4; then compound 3.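

In this assay the ethyl chain adds a third point to the plain chains, and the number falls in order across ethyl, propyl and butyl, with a 3.1-fold higher number from compound 1 to compound 4 (0.49 log units; beyond the scatter) and a 7.0-fold higher number from compound 2 to compound 4 (0.84 log units; beyond the scatter) as the chain shortens. Even this shortest chain stands well clear of the 1,3-oxazol-4-yl, with a 12-fold lower number from compound 3 to compound 4 (1.07 log units; beyond the scatter) despite having no ring and fewer heavy atoms. No evidence here explains either difference. The compounds shown leave open whether a pentyl or longer chain lowers the number further, and how a phenyl ring or an amine at this aromatic carbon would compare.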